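The source may hold more compounds than are shown below. What is called first, only, known or untested is meant among the compounds shown, and "the series" means these compounds.

Values in a functional assay (aorta) with Rattus norvegicus as the target; a higher number here means that more compound is needed for the effect, a lower number that less compound is needed:

- compound 1 `CNC(=N)Nc1nc(-c2ccc(OC)cc2)c(-c2ccc(OC)cc2)s1`: 1.2 uM
- compound 2 `COc1ccc(-c2nc(C(=O)N=C(N)N)sc2-c2ccc(OC)cc2)cc1`: > 100 uM (a limit)
- compound 3 `COc1ccc(-c2nc(/C=C/C(=O)O)sc2-c2ccc(OC)cc2)cc1`: not yet measured

For compound 2 the assay gives no number, only the limit > 100 uM. Compound 3 carries 2-carboxyethenyl on the same aromatic carbon, and the change is a group of 5 heavy atoms (3 carbon, 2 oxygen; no ring) in place of a group of 6 heavy atoms (2 carbon, 3 nitrogen, 1 oxygen; no ring), on an aromatic carbon. Among the measured compounds shown here, the only measured step at this place is an at least 83-fold higher number from compound 1 to compound 2 (1.92 log units; beyond the scatter), which is large and beyond the scatter. It shows that the far lower value of compound 1 was not kept when the group there changed, but it does not test the new group. No step beyond the scatter is therefore expected in this assay, in either direction. The estimated change is a number no higher from compound 2 to compound 3 (the limit leaves the size open) and may again end in a limit. For compound 3 the expected value is 100 uM, with an estimated range from 30 uM to 300 uM.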

Compound 3, concentration for half-maximal effect: 55 uM
Beside the measured number, compound 3's estimate is 1.8-fold (0.26 log units) above it; the measured number falls inside the stated range.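

Compound 3 gives this position a real number well away from the low value of compound 1, in this assay: the step is a 46-fold higher number from compound 1 to compound 3 (1.66 log units; beyond the scatter). A second group, 2-carboxyethenyl, thus also fails to keep that low value, and this time the size of the loss is measured and is not just a bound. The other step is an at least 1.8-fold lower number from compound 2 to compound 3 (0.25 log units; that floor lies within the scatter), and its true size stays unread because its starting value is only a limit: the limit of > 100 uM in this assay, at which 1 of the 3 values shown sits.

The compounds shown leave open whether an amine or a methyl ester on this aromatic carbon would come closer to compound 1 than 2-carboxyethenyl does. They also say nothing about the two 4-methoxyphenyl groups, which are the same in all three compounds.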